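The source may hold more compounds than are shown below. What is called first, only, known or untested is meant among the compounds shown, and "the series" means these compounds.

Measured in a functional assay on A2780 cells (Homo sapiens) for cytotoxicity; a lower number here means a stronger inhibitor, a higher number a weaker inhibitor:
- compound 1 `CCc1cnc(CSc2cnc(NC(C)=O)s2)o1`: 1400 nM
- compound 2 `CC(C)C(=O)Nc1ncc(SCc2ncc(C(C)(C)C)o2)s1`: 50 nM
- compound 3 `CCc1cnc(CSc2cnc(NC(=O)C(C)C)s2)o1`: 200 nM

Compound 3 holds the middle place among these three in this assay. Only compound 2 has a lower number, and only compound 1 a higher one.

The next compound, compound 4 `CCc1cnc(CSc2cnc(NC(=O)Cc3cccnc3)s2)o1`, places (pyridin-3-yl)methyl in place of isopropyl on a carbonyl carbon.

The measured change closest to this one is at the same carbonyl carbon, a 7.0-fold lower number from compound 1 to compound 3 (0.85 log units; beyond the scatter). It shows that this place can move the number beyond the scatter. The other measured change, a 4.0-fold higher number from compound 2 to compound 3 (0.60 log units; beyond the scatter), lies elsewhere in the molecule and bears on this one only as a measure of how large steps in this short series have been. Among the compounds with values here, no measured compound carries a ring at the carbonyl carbon, so the data set no clear direction. A small rise is expected, though a step of the size seen at this place remains possible.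

The expected change is a 1.3-fold higher number from compound 3 to compound 4 (0.10 log units; within the scatter).

For compound 4 the estimated value is 250 nM, with an expected range from 70 nM to 900 nM.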

Compound 4, half-maximal inhibitory concentration: 240 nM
Compound 4: middle estimate off by 1.0-fold (0.02 log units), on the high side; the range from low to high includes it.
By their numbers in this assay, from the lowest: compound 2; then compounds 3 and 4 (each within the scatter of the next); then compound 1.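

In this assay, the carbonyl carbon accepts (pyridin-3-yl)methyl in place of isopropyl (a 1.2-fold higher number from compound 3 to compound 4 (0.08 log units; within the scatter)), so this place holds a group with a six-membered aromatic ring and a larger count of heavy atoms without a change beyond the scatter. The earlier compounds had shown only that replacing methyl with isopropyl at this place lowers the number, and the ring-bearing group also stands clear of the methyl compound (a 5.8-fold lower number from compound 1 to compound 4 (0.77 log units; beyond the scatter)). The data shown offer no explanation for either step.

Still open, on these data alone, is whether the ring nitrogen matters at this place, which a plain phenyl group on the same chain carbon would test. Also open, as far as these compounds go, is how this place responds to a longer chain, an amine or a carboxylic acid.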